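The source may hold more compounds than are shown below. What is called first, only, known or untested is meant among the compounds shown, and "the series" means these compounds.

Series notes. In a functional assay on Venous blood for antagonist activity at C-X-C chemokine receptor type 3 (Homo sapiens), read by flow cytometry, with a stated time of 30 min, in the presence of a further agent that is not named here (on this read-out lower numbers stand for stronger inhibition and higher numbers for weaker inhibition), compound 1 `Cc1nc(C)n(CC(=O)N2CCN(c3sc(C(F)(F)F)nc3-c3nc4ccc(OC5COC5)cc4[nH]3)C[C@H]2C)n1` gives 1480 nM. Compound 2 `Cc1nc(C)n(CC(=O)N2CCN(c3sc(C(F)(F)F)nc3-c3nc4ccccc4[nH]3)C[C@H]2C)n1` gives 237 nM in this assay. Compound 3 `Cc1nc(C)n(CC(=O)N2CCN(c3sc(C(F)(F)F)nc3-c3nc4ccc(C5CCN(C)CC5)cc4[nH]3)C[C@H]2C)n1` gives 84.7 nM, the lowest of the three numbers; compound 2 stands nearest (a 2.8-fold lower number from compound 2 to compound 3 (0.45 log units; beyond the scatter)) and compound 1 furthest (a 17-fold lower number from compound 1 to compound 3 (1.24 log units; beyond the scatter)). The step of a 6.2-fold lower number from compound 1 to compound 2 (0.80 log units; beyond the scatter) shows the (oxetan-3-yl)oxy variant well behind the unsubstituted one. Compound 4 `Cc1nc(C)n(CC(=O)N2CCN(c3sc(C(F)(F)F)nc3-c3nc4ccc(S(C)(=O)=O)cc4[nH]3)C[C@H]2C)n1` carries methylsulfonyl in place of 1-methylpiperidin-4-yl on an aromatic carbon. Both steps into compound 3 are modest to large, and compound 1 shows that the other acceptor-bearing substituent at this carbon gave the highest number of the set. Compound 4 is therefore expected to give a higher number than compound 3, an estimated 5.9-fold higher number from compound 3 to compound 4 (0.77 log units; beyond the scatter), landing near 500 nM within 150 nM to 1600 nM.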

Compound 4, half-maximal inhibitory concentration: 959 nM
The estimate for compound 4 lay 1.9-fold (0.28 log units) below the measured number, within the range that was stated.
By their numbers in this assay, from the lowest: compound 3; then compound 2; then compounds 4 and 1 (each within the scatter of the next).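

In this assay, methylsulfonyl at this aromatic carbon stands behind the unsubstituted compound 2 (a 4.0-fold higher number from compound 2 to compound 4 (0.61 log units; beyond the scatter)) and cannot be told apart from (oxetan-3-yl)oxy (a 1.5-fold lower number from compound 1 to compound 4 (0.19 log units; within the scatter)). The change from 1-methylpiperidin-4-yl is large (an 11-fold higher number from compound 3 to compound 4 (1.05 log units; beyond the scatter)), so among the substituents shown, only that group gives a lower number than hydrogen at this carbon. No measurement here bears on the reason for this pattern. On these data alone, whether another amine, such as morpholine or an open-chain dimethylamino group, or a carboxylic acid at this carbon would also give a lower number than compound 2 remains open.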